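The source may report more compounds than this note shows. Statements on the series, on what has been measured and on what is new or still open speak of the compounds shown alone.

Compound 1 `COc1ccc(C(=O)/C=C/c2cc(OC)c(OC)cc2OC)cc1`: 37600 nM
Compound 2 `COc1cc(C(=O)/C=C/c2cc(OC)c(OC)cc2OC)ccc1O`: > 150000 nM, a limit of the assay, not a number
Compound 3 `COc1cc(OC)c(C2CC(=O)c3cc(O)ccc3O2)cc1OC`: > 150000 nM, likewise a limit of the assay

Going by the values given here, in a functional assay on HeLa cells (Homo sapiens) for inhibition, read by MTT assay, with a stated time of 72 h (a higher number here means a weaker inhibitor, a lower number a stronger inhibitor), compound 1 gives the only number among the three values shown; the other two sit at the limit of > 150000 nM in this assay, at which 2 of the 3 values shown sit. No pair of these compounds differs in a single place, so no measured step exists. Compound 4 `COc1cc(OC)c(OC)cc1/C=C/C(=O)c1ccc(Br)cc1` differs from compound 1 by bromo in place of methoxy on an aromatic carbon. Among the compounds with values here, with no measured step to lean on, the expected step in this assay from compound 1 to compound 4 is small, within the usual scatter, in no firm direction, estimated as a 1.3-fold lower number from compound 1 to compound 4 (0.10 log units; within the scatter). Compound 4 is therefore expected to give about 30000 nM, with a range from 8000 nM to 120000 nM.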

Compound 4, half-maximal inhibitory concentration: 31700 nM
The estimate for compound 4 lay 1.1-fold (0.02 log units) below the measured number, within the range that was stated.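

Going by these compounds alone, the only measured step in this assay is a 1.2-fold lower number from compound 1 to compound 4 (0.07 log units; within the scatter), with bromo in place of methoxy on an aromatic carbon. At this position, para to a large group, the two groups therefore read alike, so the methoxy oxygen is not needed to keep the number seen for compound 1. Nothing shown bears on why the two groups read alike. As far as these compounds go, whether an amine or a carboxylic acid at this position would read the same stays open. So does whether any single change elsewhere on the core would move the number beyond the scatter.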